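The source may report more compounds than this note shows. Statements on the series, on what has been measured and on what is new or still open speak of the compounds shown alone.

Measured compounds in an assay on isolated protein for binding affinity to cysteinyl leukotriene receptor 1 (Cavia porcellus); on this read-out higher numbers stand for weaker inhibition and lower numbers for stronger inhibition:
compound 1 `c1ccc2nc(COc3ccc(CCc4nnn[nH]4)cc3)ccc2c1` gives 160 nM
compound 2 `c1ccc2nc(COc3ccc(SCCCc4nnn[nH]4)cc3)ccc2c1` gives 31 nM
compound 3 `c1ccc2nc(COc3ccc(OCCCc4nnn[nH]4)cc3)ccc2c1` gives 69 nM

Compound 3 holds the second highest of the three numbers in this assay. Both neighbouring steps lie beyond the scatter: a 2.2-fold higher number from compound 2 to compound 3 (0.35 log units; beyond the scatter), and a 2.3-fold lower number from compound 1 to compound 3 (0.37 log units; beyond the scatter). Compound 3 therefore sits between the two other measured compounds, nearer to compound 2.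

Compound 4 `O=C(O)CCCOc1ccc(OCc2ccc3ccccc3n2)cc1` differs from compound 3 in one place: carboxy in place of 1H-tetrazol-5-yl on a saturated chain carbon, three bonds along the chain from an oxygen on an aromatic ring. Within the data shown here, no measured step covers this exchange. The three steps that are known, a 5.2-fold lower number from compound 1 to compound 2 (0.71 log units; beyond the scatter), a 2.3-fold lower number from compound 1 to compound 3 (0.37 log units; beyond the scatter) and a 2.2-fold higher number from compound 2 to compound 3 (0.35 log units; beyond the scatter), all alter the chain between the aromatic ring and the tetrazole while the tetrazole itself is kept in every measured compound. They show that the chain matters by modest amounts, but they give no direct reading on what replacing the tetrazole with a carboxy group does, so the direction and size of the step must be taken as open.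

Among the measured compounds shown here, as a working expectation the exchange is set as a modest rise in the number, a 2.9-fold higher number from compound 3 to compound 4 (0.46 log units; beyond the scatter), since none of the measured steps argues for a drop. Compound 4 is estimated at 200 nM in this assay, with a range from 60 nM to 700 nM.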

Compound 4, inhibition constant: 1200 nM
Compound 4: the middle estimate sits 6.0-fold (0.78 log units) below what was measured, outside the stated range (above it).
By their numbers in this assay, from the lowest: compound 2; then compound 3; then compound 1; then compound 4.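

In this assay, among these compounds, the end group on the chain carries more weight than any chain change among the compounds that keep 1H-tetrazol-5-yl: carboxy in place of 1H-tetrazol-5-yl gives a 17-fold higher number from compound 3 to compound 4 (1.24 log units; beyond the scatter), a large step, whereas the earlier steps were all modest. Compound 4 also stands apart from the other two compounds, with a 39-fold higher number from compound 2 to compound 4 (1.59 log units; beyond the scatter) and a 7.5-fold higher number from compound 1 to compound 4 (0.88 log units; beyond the scatter), which makes it the weakest of the four, although these two steps alter the chain as well as the end group and so do not isolate the exchange. Nothing at hand explains the size of this loss.

Among the compounds shown here, only one chain shows the exchange, so it remains open whether carboxy costs as much on the sulfur-containing chain of compound 2 or on the shorter chain of compound 1. Also open, on these data alone, is how the position responds to other end groups, such as a primary amide or a hydroxamic acid, and whether a longer chain would recover any of the loss seen with carboxy.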